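From Compound 3 to Compound 4: A tert-Butyl Enters

The source may hold more compounds than are shown below. What is called first, only, known or untested is meant among the compounds shown, and "the series" means these compounds.

Compound 1 `COc1cccc(NN=C2C(Cl)=C(Cl)C(Cl)=C2Cl)c1`: > 3000 nM
Compound 2 `Fc1ccccc1NN=C1C(Cl)=C(Cl)C(Cl)=C1Cl`: > 3000 nM
Compound 3 `C#CC(C)(C)OC(=O)NN=C1C(Cl)=C(Cl)C(Cl)=C1Cl`: "not determined" (no result reported)

All three compounds share one core and differ only in the group hanging from the hydrazone nitrogen. In a functional assay on MM1.S cells (Homo sapiens) for cytotoxicity, read by MTT assay, with a stated time of 48 h (on this read-out lower numbers stand for stronger inhibition and higher numbers for weaker inhibition), compound 1 gives > 3000 nM, which is a limit of the assay rather than a number. In this assay compound 2 gives > 3000 nM, again a limit rather than a number. In this assay compound 3 gives "not determined" (no result reported), so it cannot be placed among the others; what surrounds it is the limit of > 3000 nM in this assay, at which 2 of the 3 values shown sit.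

Compound 4 `CC(C)(C)C(=O)NN=C1C(Cl)=C(Cl)C(Cl)=C1Cl` is not yet measured. It differs from compound 3 by tert-butyl in place of (1,1-dimethylprop-2-yn-1-yl)oxy on a carbonyl carbon. Among the compounds with values here, with no measured step to lean on, the expectation for this change is no shift in this assay that can be told apart from the usual scatter. Compound 4 is therefore estimated at 3000 nM, within 1000 nM to 10000 nM, with a real chance that only a limit is reported.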

Compound 4, half-maximal inhibitory concentration: 2000 nM
Estimate against measurement, compound 4: 1.5-fold (0.18 log units) above; measured number inside the range.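

In this assay, within the data shown here, compound 3 has no reported result, so no step to compound 4 can be read. The compounds shown leave open whether tert-butyl in place of (1,1-dimethylprop-2-yn-1-yl)oxy on a carbonyl carbon shifts the read-out at all, and the other values offer only a limit: the limit of > 3000 nM in this assay, at which 2 of the 4 values shown sit.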